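A Single Stereocentre Changed in a Cytotoxic Pair

A few compounds are considered here, and "the series" means these few. Any claim that something is new, unique, unknown or untested is made for them only; others in the source may bear on it.

The measured compounds, in a functional assay on P388 cells (Mus musculus) for cytotoxicity; on this read-out lower numbers stand for an effect already at smaller amounts and higher numbers for an effect only at larger amounts of compound:
compound 1 `CC(=O)O[C@H]1C[C@H](C)[C@H]2C[C@H]2C2=C(COC2=O)[C@H]1[C@H](C)CCC=C(C)C` gives > 10 ug/mL, which is a limit of the assay rather than a number.
compound 2 `CC(=O)O[C@@H]1C(=O)C2C1CC/C=C(\C)CC[C@@H]2[C@H](C)CCC=C(C)C` gives 4.4 ug/mL.

For the measured compounds named here, compound 2 thus holds the only actual number in this assay, since the other value is a limit (the limit of > 10 ug/mL in this assay, at which 1 of the 2 values shown sits). Going by the values given here, compound 1 and compound 2 differ in many places at once, so no single step between them can be read. Compound 3 `CC(=O)O[C@H]1C(=O)C2C1CC/C=C(\C)CC[C@@H]2[C@H](C)CCC=C(C)C` is not yet measured; it differs from compound 2 only in this way: the two compounds have the same atoms and bonds; at least one stereo element is drawn with a configuration in one of them and without one in the other: 1 of 6 stereo elements differ; a stereocentre at a saturated ring carbon is drawn S in compound 2 and R in compound 3. Turning one stereocentre on a saturated ring carbon keeps every atom and bond in place, so the expected step from compound 2 to compound 3 is small, likely no more than the usual scatter, with no clear direction. Compound 3 is therefore expected to give about 5 ug/mL, within 1.5 ug/mL to 15 ug/mL, an estimated step of a 1.1-fold higher number from compound 2 to compound 3 (0.06 log units; within the scatter).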

Compound 3, concentration for half-maximal effect: 6 ug/mL
Compound 3: the middle estimate sits 1.2-fold (0.08 log units) below what was measured; the range from low to high includes it.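

For the compounds shown here, this is the first comparison here in which only one place differs, and in this assay turning the stereocentre at a saturated ring carbon from S to R gives a 1.4-fold higher number from compound 2 to compound 3 (0.13 log units; within the scatter). Compounds 2 and 3 therefore cannot be told apart on this read-out, so the drawn configuration at this one carbon leaves no readable mark on cytotoxicity toward these cells. One caution applies to this pair: the fact that one of compounds 2 and 3 is drawn with a defined configuration and the other without, at the place where they differ

The compounds shown leave open whether the other stereocentres would prove equally silent if turned one at a time. They also leave open whether the number would move if a different group, such as a free hydroxyl or an amine, stood in place of the acetate shared by compound 2 and compound 3.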